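Replacing 3-methylbenzyl with phenyl on the shared core

The source may report more compounds than this note shows. Statements on the series, on what has been measured and on what is new or still open speak of the compounds shown alone.

Within the data shown here, the three measured members share a core and differ in the group carried on the five-membered aromatic ring with 2 nitrogen. In an in vitro functional assay on cells for agonist activity at Bombesin receptor subtype-3 (Homo sapiens), read by luminescence and calcium flux (on this read-out higher numbers stand for an effect only at larger amounts of compound and lower numbers for an effect already at smaller amounts), compound 1 `CCCCc1cnc(C(CCCC)Cc2ccc(-c3ccccc3C(=O)O)cc2)[nH]1` gives 2660 nM, compound 2 `CCC(C)(C)Cc1c[nH]c(CCc2ccc(-c3ccccc3C(=O)O)cc2)n1` gives 25 nM, and compound 3 `Cc1cccc(Cc2cnc(CCc3ccc(-c4ccccc4C(=O)O)cc3)[nH]2)c1` gives 4310 nM. Compound 3 stands at the highest number of the three; its number and that of compound 1 lie within the scatter of each other, while compound 2 stands far below it, beyond the scatter.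

Compound 4 `O=C(O)c1ccccc1-c1ccc(CCc2ncc(-c3ccccc3)[nH]2)cc1` is not yet measured. It differs from compound 3 in one place: phenyl in place of 3-methylbenzyl on an aromatic carbon. Among the measured compounds shown here, no step between measured compounds isolates this change, so the expectation rests on the spread of the three numbers alone. Compound 3 and compound 1 show that two rather different groups on the aromatic carbon can give similar high numbers, and compound 2 shows that another group can give a far lower one; phenyl cannot be tied to either outcome from these data. The step from compound 3 to compound 4 is expected to be a 2.2-fold lower number from compound 3 to compound 4 (0.33 log units; beyond the scatter), with either direction possible. Compound 4 is estimated at 2000 nM in this assay, in a range from 400 nM to 10000 nM.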

Compound 4, half-maximal effective concentration: 4950 nM
Estimate against measurement, compound 4: 2.5-fold (0.39 log units) below; the measured number falls inside the stated range.
By their numbers in this assay, from the lowest: compound 2; then compounds 1, 3 and 4 (each within the scatter of the next).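

Phenyl in place of 3-methylbenzyl on the aromatic carbon gives a 1.1-fold higher number from compound 3 to compound 4 (0.06 log units; within the scatter) in this assay, the first step in the series that isolates a single change at this position. The two groups are thus interchangeable here on this read-out, and neither brings the number near that of compound 2, which gives 25 nM with its branched alkyl group at this position. Nothing at hand accounts for this similarity between the two groups.

The low number of compound 2 remains tied to that one branched group, since compound 1, with a butyl group here, also differs in the chain on the shared core. On these data alone, what an amine, a hydroxyl or a longer branched chain on this aromatic carbon would give remains open.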